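Chloro for fluoro: from compound 3 to compound 4

The source may hold more compounds than are shown below. What is called first, only, known or untested is meant among the compounds shown, and "the series" means these compounds.

Compound 2 `CC1=NN(C(=O)CCl)C(c2cc(F)ccc2O)C1` and compound 1 `CC1=NN(C(=O)CCl)C(c2cc(Cl)ccc2O)C1` share one core and differ only in the halogen on the phenol ring. In a functional assay on SGC-7901 cells (Homo sapiens) for antiproliferative activity, read by MTT assay, with a stated time of 48 h (on this read-out lower numbers stand for an effect already at smaller amounts and higher numbers for an effect only at larger amounts of compound), compound 2 gives 7000 nM, and compound 1 gives 14000 nM. The change chloro in place of fluoro on an aromatic carbon thus made a 2.0-fold higher number from compound 2 to compound 1 (0.30 log units; within the scatter), so the two compounds are read as level.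

Compound 3 `CC1=NN(S(=O)(=O)c2ccc(F)cc2)C(c2cc(Br)ccc2O)C1` carries a different core; the difference between its core and that of compound 2 is not broken down here. In this assay compound 3 reaches only a limit, > 60000 nM. That limit is the limit of > 60000 nM in this assay, at which 1 of the 3 values shown sits.

Compound 4 `CC1=NN(S(=O)(=O)c2ccc(Cl)cc2)C(c2cc(Br)ccc2O)C1`, not yet measured, differs from compound 3 by chloro in place of fluoro on an aromatic carbon. The surroundings of the site are not the same as in the earlier pair: in compound 1 the new chloro stands meta to a large group and para to a hydroxy group, whereas in compound 4 it stands para to a large group. It is therefore the same kind of change, not the same change.

The expected step of a number no higher from compound 3 to compound 4 (the limit leaves the size open) rests on the earlier pair, where a 2.0-fold higher number from compound 2 to compound 1 (0.30 log units; within the scatter) stayed within the scatter, and on compound 3 sitting at the limit of > 60000 nM in this assay, at which 1 of the 3 values shown sits, so the new compound is also expected to return a limit rather than a number. Compound 4 is estimated at 60000 nM, with a range from 30000 nM to 120000 nM.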

Compound 4, half-maximal effective concentration: > 60000 nM
Compound 4: only a limit was reported; the forecaster's own chance of this, stated with the estimate: 75%; the middle value sits exactly at the limit.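

In this assay compound 3 and compound 4 each return only a limit, so the step from 4-fluorophenyl to 4-chlorophenyl cannot be read: the limit of > 60000 nM in this assay, at which 2 of the 4 values shown sit. The compounds shown leave open whether this exchange of fluoro for chloro on the aromatic ring changes the antiproliferative read-out at all, and where either compound would stand if it gave a number rather than a limit.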